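The source may report more compounds than this note shows. Statements on the series, on what has been measured and on what is new or still open speak of the compounds shown alone.

Of the compounds shown here, two sharing one core have so far been measured for solubility. Compound 1 `CCCCC(=O)N1CCN(c2nc(=O)c3cc(C(F)(F)F)cc([N+](=O)[O-])c3s2)CC1` in a physicochemical assay for solubility, read by HPLC (on this read-out higher numbers stand for higher solubility and lower numbers for lower solubility), gives 42.5 ug/mL. Compound 2 `CCCC(=O)N1CCN(c2nc(=O)c3cc(C(F)(F)F)cc([N+](=O)[O-])c3s2)CC1` in this assay gives 2.46 ug/mL, the lower of the two numbers; its nearest neighbour is compound 1, which stands well above it. For the measured compounds named here, the only measured step, a 17-fold lower number from compound 1 to compound 2 (1.24 log units; beyond the scatter), shows that a change as small as one methyl at the end of the chain can move the read-out a long way.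

Compound 3 `CC(C)(C)C1CCC(C(=O)N2CCN(c3nc(=O)c4cc(C(F)(F)F)cc([N+](=O)[O-])c4s3)CC2)CC1` arises from compound 2 by 4-(tert-butyl)cyclohexyl in place of propyl on a carbonyl carbon. Going by the values given here, this is a change of a different kind and of far greater size than the measured step: the whole chain is exchanged for a larger group that contains a ring, and no measured pair covers such an exchange. Going by these compounds, the measured step ran toward higher numbers as the chain grew by one carbon, but it is a weak guide here, so the direction remains open and a wide range is appropriate. Compound 3 is expected to give about 1 ug/mL in this assay, within a range from 0.1 ug/mL to 8 ug/mL. That estimate corresponds to an expected step of a 2.5-fold lower number from compound 2 to compound 3 (0.39 log units; beyond the scatter).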

Compound 3, solubility: < 0.1 ug/mL
Compound 3: a limit, no number; the forecaster's own chance of this, stated with the estimate: 25%; middle value at least 10-fold (1.00 log units) away from the limit.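

The carbonyl carbon now proves sensitive to a far larger exchange than the loss of one methyl: 4-(tert-butyl)cyclohexyl in place of propyl gives an at least 24-fold lower number from compound 2 to compound 3 (1.39 log units; beyond the scatter), and the same group in place of butyl gives an at least 420-fold lower number from compound 1 to compound 3 (2.62 log units; beyond the scatter). For compound 3 the read-out is a limit and not a number, so both steps give only a smallest size: the limit of < 0.1 ug/mL in this assay, at which 1 of the 3 values shown sits. Until now only butyl and propyl could be compared, with the longer chain giving the higher number, but compound 3 goes against any simple rule that a larger group here gives a higher number, since its 10 carbon atoms and six-membered ring go with the lowest reading of the three.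

The compounds shown do not separate the part played by the ring from that played by the tert-butyl, nor do they show where between butyl and 4-(tert-butyl)cyclohexyl the read-out turns downward. A plain cyclohexyl, a longer straight chain such as hexyl, or a chain ending in an amine on the same carbonyl carbon would each help to fill that gap.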